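Chloro for methyl on the core of compound 3

The compounds below may be only part of what the source reports. "The series", "measured", "known", "first", "only" and "open" are said of these compounds alone.

Compound 3 `Cc1cn(Cc2cc(Br)ccc2OCc2ccccc2)nc1C(=O)O` gives 1350 nM in a functional assay on CHO-K1 cells for antagonist activity at prostaglandin E2 receptor EP1 subtype (Homo sapiens), read by FLIPR; on this read-out lower numbers stand for stronger inhibition and higher numbers for weaker inhibition. Of the two numbers shown in this assay it stands highest; its nearest neighbour compound 1 `Cc1cc(C(=O)O)nn1Cc1cc(Br)ccc1OCc1ccccc1` gives 15.1 nM in this assay, a gap well beyond the scatter. Compound 2 `CC(=O)Nc1cc(C(=O)O)nn1Cc1cc(Br)ccc1OCc1ccccc1` gives in this assay only a limit, < 2000 nM, not a number. Among the measured compounds shown here, the single measured step that the limit leaves unreadable from compound 1 to compound 2 therefore cannot be sized because of the limit of < 2000 nM in this assay, at which 1 of the 3 values shown sits.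

Compound 4 `O=C(O)c1nn(Cc2cc(Br)ccc2OCc2ccccc2)cc1Cl` differs from compound 3 by chloro in place of methyl on an aromatic carbon. No measured step exchanges methyl for chloro; the only measured step, from compound 1 to compound 2, concerns acetamido and is unreadable, so nothing among the numbers shown sizes the present change. The working expectation is therefore a step of no change at the digits printed from compound 3 to compound 4 (within the scatter) in this assay, that is, none beyond the scatter. Compound 4 is estimated at 1350 nM in this assay, with a range from 450 nM to 4000 nM.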

Compound 4, inhibition constant: < 2000 nM
Compound 4: a limit, no number; the forecaster's own chance of this, stated with the estimate: 30%; the middle value lies beyond the limit too.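

Compound 4 gives only a limit, so no step from compound 3 to compound 4 can be read in this assay, and the cause is this: the limit of < 2000 nM in this assay, at which 2 of the 4 values shown sit.

On these data alone, whether chloro in place of methyl on the shared core of compound 3 and compound 4 shifts the inhibition constant at all stays open.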